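Pyrrolyl for piperidinyl on the chain carbon of compound 2

A few compounds are considered here, and "the series" means these few. Any claim that something is new, unique, unknown or untested is made for them only; others in the source may bear on it.

Among the measured compounds shown here, compound 2 `Cc1n[nH]cc1-c1cc2nc(CN3CCCCC3)[nH]c(=O)c2s1` holds the lowest of the two numbers so far in an assay for inhibition of Rho-associated protein kinase 1 (Homo sapiens), read by TR-FRET, with stated times of 5 min and 2 h (on this read-out lower numbers stand for stronger inhibition and higher numbers for weaker inhibition), where compound 2 gives 200 nM. For the measured compounds named here, the only other measured member, compound 1 `CCOCc1nc2cc(-c3c[nH]nc3C)sc2c(=O)[nH]1`, gives 2100 nM in this assay. Going by the values given here, the single measured step, an 11-fold lower number from compound 1 to compound 2 (1.02 log units; beyond the scatter), concerns the same saturated chain carbon bound to an aromatic carbon and shows that this position is sensitive to what sits on it. Compound 3 `Cc1n[nH]cc1-c1cc2nc(Cn3cccc3)[nH]c(=O)c2s1` differs from compound 2 in that position only: 1H-pyrrol-1-yl in place of piperidin-1-yl on a saturated chain carbon bound to an aromatic carbon. Among the compounds with values here, no measured step covers a swap of piperidin-1-yl for 1H-pyrrol-1-yl, so the direction rests on the size of the one step seen, which moved the number strongly when the group here changed. A step back toward compound 1 is expected, of the size a 5.0-fold higher number from compound 2 to compound 3 (0.70 log units; beyond the scatter). For compound 3 the estimate in this assay is 1000 nM, with a range from 300 nM to 4000 nM.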

Compound 3, half-maximal inhibitory concentration: 370 nM
Estimate against measurement, compound 3: 2.7-fold (0.43 log units) above; the range from low to high includes it.
By their numbers in this assay, from the lowest: compounds 2 and 3 (each within the scatter of the next); then compound 1.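

On the saturated chain carbon bound to an aromatic carbon, 1H-pyrrol-1-yl in place of piperidin-1-yl gives a 1.9-fold higher number from compound 2 to compound 3 (0.27 log units; within the scatter) in this assay so that a five-membered aromatic ring and a six-membered non-aromatic ring cannot be told apart at this position. With 1H-pyrrol-1-yl in place of ethoxy there is a 5.7-fold lower number from compound 1 to compound 3 (0.75 log units; beyond the scatter) and the lower number relative to ethoxy is therefore not confined to piperidin-1-yl. Nothing at hand bears on the reason for these numbers.

Open, as far as these compounds go, is whether a ring on this carbon matters at all, which an open-chain dimethylamino group would test. Also open, from the compounds shown here alone, is how a carboxylic acid or a longer chain carrying piperidin-1-yl would read in this assay on the shared core.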